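A few compounds are considered here, and "the series" means these few. Any claim that something is new, unique, unknown or untested is made for them only; others in the source may bear on it.

Of the compounds shown here, three from this series have been tested, and all of them share the same core. Compound 1 `N#CCN(Cc1ccccc1)Cc1ccc2ccccc2c1` carries a larger aromatic group on the amine, compound 3 `N#CCN(Cc1ccccc1)Cc1ccc2ccccc2n1` a related aromatic group containing nitrogen, and compound 2 `N#CCN(Cc1ccccc1)Cc1ccc(Cl)cc1` a chloro group on an aromatic carbon. In an assay on HEK293 cells for binding affinity to Substance-K receptor (Rattus norvegicus), read by FRET, tested at 10 uM (on this read-out higher numbers stand for more inhibition at the one concentration tested (going by the name of the read-out) and lower numbers for less inhibition), compound 1 gives 0%, compound 3 gives 0%, and compound 2 gives 0%. Compound 2 therefore stands level with compound 1 and compound 3 at the digits recorded, all three lying within the scatter of one another and showing no inhibition at the single concentration tested.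

The next compound, compound 4 `N#CCN(Cc1ccccc1)Cc1ccc(C(F)(F)F)cc1`, differs from compound 2 in one place: trifluoromethyl in place of chloro on an aromatic carbon, on an aromatic carbon of a six-membered aromatic ring of carbon only, para to a large group. Among the compounds with values here, since every compound measured so far shows no inhibition, the step from compound 2 to compound 4 is expected to be no change at the digits printed from compound 2 to compound 4 (within the scatter), that is, none beyond the scatter. For compound 4 the estimated value is 0%, with a range from -8% to 10%.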

Compound 4, a percentage reported as inhibition, at one concentration (the size of the read-out at that concentration, not a potency): 0%
Estimate against measurement, compound 4: no gap at the digits printed; low and high end bracket the measured number.
By their numbers in this assay, from the lowest: compounds 1, 2, 3 and 4 (each within the scatter of the next).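

In this assay, the exchange on an aromatic carbon of a six-membered aromatic ring of carbon only, para to a large group, gives no change at the digits printed from compound 2 to compound 4 (within the scatter). Within the data shown here, this is the first direct comparison at this position, and it shows that trifluoromethyl, with 4 heavy atoms, reads the same as chloro, with 1 heavy atom. Neither compound shows inhibition at the one concentration tested, so the pair cannot rank the two groups, and nothing available explains the result.

From the compounds shown here alone, it remains open whether a different group at this position, such as an amine or a carboxylic acid, would give any inhibition at all. Going by these compounds, it is equally open whether replacing the nitrile of the shared core with an amide would do so.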